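The source may report more compounds than this note shows. Statements on the series, on what has been measured and on what is new or still open speak of the compounds shown alone.

Compound 1 `CCN(CC)c1ccc2cc(C(=O)c3ccc(N4CCN(S(C)(=O)=O)CC4)cc3)oc2c1` carries a methylsulfonyl group on an amine nitrogen in a ring. In a functional assay on A549 cells (Homo sapiens) for cytotoxicity, read by MTT assay, with a stated time of 48 h (a higher number here means a weaker inhibitor, a lower number a stronger inhibitor), compound 1 gives > 40000 nM, which is a limit of the assay and not a number. Compound 2 `CCN(CC)c1ccc2cc(C(=O)c3ccc(N4CCN(S(=O)(=O)c5ccc(Br)c(F)c5)CC4)cc3)oc2c1` gives 15100 nM in this assay. Compound 3 `CCN(CC)c1ccc2cc(C(=O)c3ccc(N4CCN(S(=O)(=O)c5ccc(C)cc5)CC4)cc3)oc2c1` gives > 40000 nM in this assay, again a limit. The picture is dominated by the limit of > 40000 nM in this assay, at which 2 of the 3 values shown sit. Two steps at this position are readable: an at least 2.6-fold lower number from compound 1 to compound 2 (0.42 log units; beyond the scatter) and an at least 2.6-fold higher number from compound 2 to compound 3 (0.42 log units; beyond the scatter), while a step that the two limits leave unreadable from compound 1 to compound 3. Compound 4 `CCN(CC)c1ccc2cc(C(=O)c3ccc(N4CCN(C(C)=O)CC4)cc3)oc2c1` differs from compound 1 in one place: acetyl in place of methylsulfonyl on an amine nitrogen in a ring. For the measured compounds named here, no measured step involves an acetyl group. For compound 4 the expected step is a number no higher from compound 1 to compound 4 (the limit leaves the size open). The estimate for compound 4 is 40000 nM, with a range from 15000 nM to 100000 nM.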

Compound 4, half-maximal inhibitory concentration: 30100 nM
Compound 4: the middle estimate sits 1.3-fold (0.12 log units) above what was measured; measured number inside the range.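

Compound 4 shows that a group without sulfur on this amine nitrogen can still give a readable value in this assay. Against the two compounds held at a limit, the result is an at least 1.3-fold lower number from compound 1 to compound 4 (0.12 log units; that floor lies within the scatter) and an at least 1.3-fold lower number from compound 3 to compound 4 (0.12 log units; that floor lies within the scatter), and neither floor establishes a real change because the true size of both steps stays open: the limit of > 40000 nM in this assay, at which 2 of the 4 values shown sit.

Against the one other readable compound, the result is a 2.0-fold higher number from compound 2 to compound 4 (0.30 log units; within the scatter), so acetyl and (4-bromo-3-fluorophenyl)sulfonyl cannot be told apart here. Still open, as far as these compounds go, is how a benzoyl group or a plain ethyl chain on this nitrogen would read.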